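This account rests on a few compounds, and the source may have more. Where it says the series, first, only, none or still open, it means among the compounds named here.

Compound 1 `COc1cccc2c1nc(-c1c(F)cccc1F)n2Cc1c(F)cccc1F`, compound 2 `Fc1cccc(F)c1Cn1c(-c2c(F)cccc2F)nc2c(Cl)cccc21` and compound 3 `CC(=O)N(C)c1cccc2c1nc(-c1c(F)cccc1F)n2Cc1c(F)cccc1F` have been tested in a toxicity assay on CCRF-CEM cells (Homo sapiens) for cytotoxicity (a higher number here means that more compound is tolerated, a lower number that less compound is tolerated), and compound 4 `CN(C)c1cccc2c1nc(-c1c(F)cccc1F)n2Cc1c(F)cccc1F` has not. Compound 1 gives 44.3 uM, and compound 2 gives 30.4 uM. Chloro in place of methoxy is thus a 1.5-fold lower number from compound 1 to compound 2 (0.16 log units; within the scatter).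

Compound 3 stands at > 100 uM, which is a limit of this assay and not a number.

Compound 4 carries methyl in place of acetyl on a nitrogen on an aromatic ring, turning acetyl(methyl)amino into dimethylamino. For the measured compounds named here, two measured steps bear on this, since both introduce the group now being changed: an at least 2.2-fold higher number from compound 1 to compound 3 (0.35 log units; beyond the scatter) and an at least 3.2-fold higher number from compound 2 to compound 3 (0.51 log units; beyond the scatter). Compound 4 loses the acetyl, so a lower number is expected, close to compound 1 at 44.3 uM and compound 2 at 30.4 uM. The limit on compound 3 leaves the size of the drop open, and dimethylamino has not been measured here, so the range is wide. The expected change is an at least 2.5-fold lower number from compound 3 to compound 4 (0.39 log units; beyond the scatter). Compound 4 is estimated at 40 uM, with an expected range of 15 uM to 100 uM.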

Compound 4, half-maximal toxic concentration: > 100 uM
Compound 4: a limit, no number; the forecaster's own chance of this, stated with the estimate: 15%; middle value at least 2.5-fold (0.39 log units) away from the limit.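

In this assay, the acetyl on this nitrogen is not required for a result at the limit, since dimethylamino in the same place gives an at least 3.2-fold higher number from compound 2 to compound 4 (0.51 log units; beyond the scatter) and an at least 2.2-fold higher number from compound 1 to compound 4 (0.35 log units; beyond the scatter). Both nitrogen groups tested here, acetyl(methyl)amino and dimethylamino, therefore stand apart from methoxy and chloro, which compound 3 alone could not show for a nitrogen group without the carbonyl. The step from compound 3 to compound 4 cannot be read, because each compound stands at a limit and not at a number: the limit of > 100 uM in this assay, at which 2 of the 4 values shown sit.

From the compounds shown here alone, whether acetyl and methyl differ at all on this nitrogen remains open, as does the true number for compound 3 and compound 4. Also open, going by these compounds, is whether a plain amine or a longer chain on the nitrogen, such as ethyl, would behave like dimethylamino.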